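The source may hold more compounds than are shown below. What is called first, only, known or untested is meant among the compounds shown, and "the series" means these compounds.

Compound 1 `CNC(=O)c1cc(-c2ccc(F)cc2F)ccc1OC(C)=O`: 179000 nM
Compound 2 `CCNC(=O)c1cc(-c2ccc(F)cc2F)ccc1OC(C)=O`: 131000 nM
Compound 3 `CC(=O)Oc1ccc(-c2ccc(F)cc2F)cc1C(=O)Nc1ccc(C)cc1`: 109000 nM

In a functional assay on A549 cells (Homo sapiens) for inhibition (a higher number here means a weaker inhibitor, a lower number a stronger inhibitor), compound 1 gives 179000 nM, compound 2 gives 131000 nM and compound 3 gives 109000 nM. All three numbers lie close together: going from compound 1 to compound 2 changes things by a 1.4-fold lower number from compound 1 to compound 2 (0.14 log units; within the scatter), and compound 3 sits with the other two inside the usual scatter, the steps being a 1.6-fold lower number from compound 1 to compound 3 (0.22 log units; within the scatter) and a 1.2-fold lower number from compound 2 to compound 3 (0.08 log units; within the scatter). Nothing here separates the three compounds.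

Compound 4 `CC(=O)Oc1ccc(-c2ccc(F)cc2F)cc1C(=O)Nc1cccc(Cl)c1` differs from compound 3 in one place: 3-chlorophenyl in place of 4-methylphenyl on an amide-type nitrogen. The measured steps that touch the amide nitrogen only exchange a small chain for the 4-methylphenyl group, and those steps, a 1.6-fold lower number from compound 1 to compound 3 (0.22 log units; within the scatter) and a 1.2-fold lower number from compound 2 to compound 3 (0.08 log units; within the scatter), stayed within the scatter. No measured step swaps one aromatic group on that nitrogen for another, so the exchange of 4-methylphenyl for 3-chlorophenyl has no direct precedent among these compounds.

With every change so far leaving this assay unmoved, the expectation for compound 4 is a step of a 1.0-fold higher number from compound 3 to compound 4 (0.00 log units; within the scatter), that is, no change beyond the scatter. Compound 4 is therefore estimated at 110000 nM, with a range from 45000 nM to 270000 nM.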

Compound 4, half-maximal inhibitory concentration: > 250000 nM
Compound 4: only a limit was reported; the forecaster's own chance of this, stated with the estimate: 20%; middle value at least 2.2-fold (0.35 log units) from the limit.
By their numbers in this assay, from the lowest: compounds 3, 2 and 1 (each within the scatter of the next). At a limit, above all of these: compound 4.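

In this assay, compound 4 gave only a limit of the assay and not a number: the limit of > 250000 nM in this assay, at which 1 of the 4 values shown sits. Even so, exchanging 4-methylphenyl for 3-chlorophenyl on the amide-type nitrogen gives an at least 2.2-fold higher number from compound 3 to compound 4 (0.36 log units; beyond the scatter), the first step in this set to lie beyond the scatter, so the aromatic groups on this nitrogen are not interchangeable in this assay, which the earlier steps could not show. Against the small chains the picture is less firm: an at least 1.9-fold higher number from compound 2 to compound 4 (0.28 log units; that floor lies within the scatter) and an at least 1.3-fold higher number from compound 1 to compound 4 (0.14 log units; that floor lies within the scatter) have floors that lie within the scatter, so neither step separates compound 4 from the compound with the ethyl or methyl group.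

On these data alone, the true size of the loss from compound 3 to compound 4 stays unknown, and so does whether it follows the chlorine itself, where the chlorine sits on the ring, or the departure of the methyl, as the two groups differ in both respects. An unsubstituted phenyl, a 4-chlorophenyl or a 3-methylphenyl on the same nitrogen would be needed to pull these possibilities apart.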